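Aryl variation at the saturated ring carbon: cytotoxicity notes

The compounds below may be only part of what the source reports. "The series", "measured", "known", "first", "only" and "open" are said of these compounds alone.

Measured so far:
compound 1 `N#CC1=C(N)N(c2ccc(S(N)(=O)=O)cc2)C2=C(CCCC2)C1c1ccccc1O`, in a functional assay on Ehrlich cells (Mus musculus) for cytotoxicity, read by trypan blue exclusion, with a stated time of 2 h, tested at 25 ug/mL (a lower number here means a weaker effect, a higher number a stronger effect of the compound at the concentration tested), compound 1 gives 40%
compound 2 `N#CC1=C(N)N(c2ccc(S(N)(=O)=O)cc2)C2=C(CCCC2)C1c1cccc([N+](=O)[O-])c1`, compound 2 gives 1%
compound 3 `N#CC1=C(N)N(c2ccc(S(N)(=O)=O)cc2)C2=C(CCCC2)C1c1ccccc1Cl`, compound 3 gives 0%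

Compound 3 stands at the bottom of the three numbers, though its gap to compound 2 lies within the scatter; only compound 1 sits clearly apart, a number 40 percentage points lower from compound 1 to compound 3 (beyond the scatter). Compound 4 `N#CC1=C(N)N(c2ccc(S(N)(=O)=O)cc2)C2=C(CCCC2)C1c1ccc(Cl)cc1Cl` differs from compound 3 by chloro in place of hydrogen on an aromatic carbon. Among the measured compounds shown here, no measured step matches this change. For the measured compounds named here, the steps that bear on it are a number 40 percentage points lower from compound 1 to compound 3 (beyond the scatter), large, and a number 1 percentage points lower from compound 2 to compound 3 (within the scatter), within the scatter: once the 2-hydroxyphenyl is gone, the numbers sit near zero regardless of the aryl group. A further chloro is therefore expected to give no step beyond the scatter, a number 2 percentage points higher from compound 3 to compound 4 (within the scatter). Compound 4 is estimated at 2%, between 0% and 12%.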

Compound 4, a percentage reported as activity, at one concentration (the size of the read-out at that concentration, not a potency): 50%
For compound 4 the middle estimate is 48 percentage points below the measured one; measured number outside the range, above it.
By their numbers in this assay, from the lowest: compounds 3 and 2 (each within the scatter of the next); then compounds 1 and 4 (each within the scatter of the next).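

In this assay this position on the aryl ring clearly matters: chloro in place of hydrogen, para to a large group, gives a number 50 percentage points higher from compound 3 to compound 4 (beyond the scatter), so the near-zero numbers seen without the 2-hydroxyphenyl do not hold for every aryl group. A hydroxy group is not required for a high number here: 2,4-dichlorophenyl gives a number 49 percentage points higher from compound 2 to compound 4 (beyond the scatter) against 3-nitrophenyl, and a number 10 percentage points higher from compound 1 to compound 4 (within the scatter) against 2-hydroxyphenyl. Nothing available explains this jump.

Still open, on these data alone, is whether the new chloro depends on the chloro already on the ring. Also open, as far as these compounds go, is whether an amine or a methoxy group in the same place would give a similar number.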